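The source may report more compounds than this note shows. Statements on the series, on what has been measured and on what is new or still open speak of the compounds shown alone.

Measured so far in an assay on HEK293 cells for negative allosteric modulation of metabotropic glutamate receptor 5 (Homo sapiens), read by FLIPR; a higher number here means a weaker inhibitor, a lower number a stronger inhibitor:
Compound 1 `O=C(N1CCC(F)CC1)N1CC(c2nc(-c3cccc(Cl)c3)no2)C1` reaches only the limit of the assay, > 10000 nM.
Compound 2 `O=S(=O)(c1ccc(F)cc1)N1CC(c2nc(-c3cccc(Cl)c3)no2)C1` gives 130 nM.
Compound 3 `O=C(C1CCC1)N1CC(c2nc(-c3cccc(Cl)c3)no2)C1` gives 1500 nM.

Among the numbers shown, compound 3 stands highest; compound 2 is its nearest neighbour with a lower number, and compound 1 shows only a limit. Compound 4 `O=C(C1CCC2(CCC2)CC1)N1CC(c2nc(-c3cccc(Cl)c3)no2)C1` differs from compound 3 by a group of 9 heavy atoms (9 carbon; one four-membered non-aromatic ring of carbon only, one six-membered non-aromatic ring of carbon only) in place of a group of 4 heavy atoms (4 carbon; one four-membered non-aromatic ring of carbon only), on a carbonyl carbon. Among the compounds with values here, the one measured step at the carbonyl carbon, an at least 6.6-fold lower number from compound 1 to compound 3 (0.82 log units; beyond the scatter), is of at least modest size, and it starts from a limit (the limit of > 10000 nM in this assay, at which 1 of the 3 values shown sits), so it tells the direction for that exchange but nothing about further growth of the ring group. Compound 4 is therefore expected to sit near compound 3, with an expected step of a 2.1-fold lower number from compound 3 to compound 4 (0.33 log units; beyond the scatter). The estimate for compound 4 in this assay is 700 nM, between 150 nM and 3000 nM.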

Compound 4, half-maximal inhibitory concentration: > 10000 nM
Compound 4 gave a limit, no number; the forecaster's own chance of this, stated with the estimate: 5%; middle value at least 14-fold (1.15 log units) away from the limit.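

At the carbonyl carbon in this assay, a larger ring group does not extend what cyclobutyl gives: the group of 9 heavy atoms in place of cyclobutyl yields an at least 6.6-fold higher number from compound 3 to compound 4 (0.82 log units; beyond the scatter). Compound 4 stands at a limit, so this step fixes a direction and not a size. The step between compound 1 and compound 4 cannot be read, because both values are limits: the limit of > 10000 nM in this assay, at which 2 of the 4 values shown sit.

As far as these compounds go, whether cyclopentyl or cyclohexyl on the carbonyl carbon would hold the level of compound 3 stays open. So does the effect of a small open chain such as isopropyl there.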